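Compound 3 to compound 4: an open cell-tolerance question

The source may hold more compounds than are shown below. What is called first, only, known or untested is meant among the compounds shown, and "the series" means these compounds.

Measured in an ADME assay on THP-1 cells (Homo sapiens) for cytotoxicity; a higher number here means that more compound is tolerated, a lower number that less compound is tolerated:
- Compound 1 `CC(C)(C)Nc1c(-c2ccccn2)nc2c(OCc3ccccc3)cccn12`: > 50000 nM, a limit
- Compound 2 `c1ccc(-c2nc3ccccn3c2Nc2ccc3c(c2)OCCO3)nc1`: 25600 nM
- Compound 3 `CC(C)(O)CNc1c(-c2ccccn2)nc2ccccn12`: > 50000 nM, a limit

Compound 3 gives > 50000 nM, which is a limit and not a number. It stands with compound 1 at one shared reading: the limit of > 50000 nM in this assay, at which 2 of the 3 values shown sit. Compound 4 `c1ccc(-c2nc3ccccn3c2NC2CCOC2)nc1` carries oxolan-3-yl in place of 2-hydroxy-2-methylpropyl on a nitrogen on an aromatic ring. Among the compounds with values here, no two measured compounds differ in only one place, so no measured step speaks to this change. A shift no larger than the usual scatter, in either direction, is expected in this assay. The estimated change is an at least 1.1-fold lower number from compound 3 to compound 4 (0.04 log units; that floor lies within the scatter). For compound 4 the expected value is 45000 nM, with an estimated range from 20000 nM to 90000 nM.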

Compound 4, half-maximal cytotoxic concentration: > 50000 nM
Compound 4: a limit, no number; the forecaster's own chance of this, stated with the estimate: 60%; middle value at least 1.1-fold (0.04 log units) away from the limit.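

Within the data shown here, compound 3 and compound 4 each give a limit and not a number in this assay, so no step between them can be read: the limit of > 50000 nM in this assay, at which 3 of the 4 values shown sit.

On these data alone, how much of either compound is tolerated, and whether oxolan-3-yl in place of 2-hydroxy-2-methylpropyl shifts that amount, stays open.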